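Replacing 2,3-dichlorophenyl in an inactive compound

The compounds below may be only part of what the source reports. "The series", "measured", "known", "first", "only" and "open" are said of these compounds alone.

In a functional assay on MCF7 cells (Homo sapiens) for cytotoxicity, read by MTT assay, with a stated time of 72 h (on this read-out lower numbers stand for stronger inhibition and higher numbers for weaker inhibition), compound 1 (`O=C(N/N=C/c1cccc(Cl)c1Cl)Nc1cc2c(Nc3ccc(F)c(Cl)c3)ncnc2cc1O[C@H]1CCOC1`) is recorded as "not active" (no number reported), so no number places it. On the same shared core, compound 2 (`CC(C)(C)c1cc(/C=N/NC(=O)Nc2cc3c(Nc4ccc(F)c(Cl)c4)ncnc3cc2O[C@H]2CCOC2)cc(C(C)(C)C)c1O`) gives 14500 nM. Compound 3 (`CCN(CC)c1ccc(/C=N/NC(=O)Nc2cc3c(Nc4ccc(F)c(Cl)c4)ncnc3cc2O[C@H]2CCOC2)c(O)c1`) carries 4-(diethylamino)-2-hydroxyphenyl in place of 2,3-dichlorophenyl on a carbon with a double bond to nitrogen. In this assay, a modest step toward stronger inhibition is expected from compound 1, ending in the range of compound 2 at 14500 nM, though a further inactive result remains possible. Compound 3 is expected at about 9000 nM, with an estimated range from 2000 nM to 40000 nM.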

Compound 3, half-maximal inhibitory concentration: 15600 nM
Compound 3: the middle estimate sits 1.7-fold (0.24 log units) below what was measured; the measured number falls inside the stated range.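

Among these compounds, compound 1 carries no number to set against compound 3, so no step between them can be read. Going by these compounds, how far apart the two lie in this assay stays open, and no evidence here bears on the result.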